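Adding one more methoxy group to compound 1

A few compounds are considered here, and "the series" means these few. Any claim that something is new, unique, unknown or untested is made for them only; others in the source may bear on it.

In a functional assay on NCI/ADR-RES cells (Homo sapiens) for inhibition, read by sulforhodamine B assay, with a stated time of 48 h (on this read-out higher numbers stand for weaker inhibition of growth and lower numbers for stronger inhibition of growth), compound 1 (`COc1ccc(/C=C/C2(C)C=CC(=O)O2)cc1OC`) gives 111000 nM as its reading. Compound 2 (`COc1cc(OC)c(OC)cc1/C=C/C1(C)C=CC(=O)O1`) gives 158000 nM in this assay as well. Going by the values given here, these are the only two numbers so far, and they lie within the scatter of each other, so compound 1 cannot be ranked apart from compound 2. Compound 3 (`COc1cc(/C=C/C2(C)C=CC(=O)O2)cc(OC)c1OC`) has not been measured. Its structure differs from compound 1 by one change (methoxy in place of hydrogen on an aromatic carbon) with the new methoxy ortho to a methoxy group. Among the compounds with values here, the one measured step of this kind of change, methoxy in place of hydrogen on an aromatic carbon, is a 1.4-fold higher number from compound 1 to compound 2 (0.15 log units; within the scatter) and stays small. No step beyond the scatter is therefore expected in this assay here. The expected step is a 1.1-fold higher number from compound 1 to compound 3 (0.05 log units; within the scatter) and no more. For compound 3 the estimated value is 125000 nM with an expected range from 60000 nM to 250000 nM around it.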

Compound 3, concentration for total growth inhibition: 123000 nM
Estimate against measurement, compound 3: 1.0-fold (0.01 log units) above; measured number inside the range.
By their numbers in this assay, from the lowest: compounds 1, 3 and 2 (each within the scatter of the next).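

In this assay the methoxy group added at this position, ortho to a methoxy group, gives a 1.1-fold higher number from compound 1 to compound 3 (0.04 log units; within the scatter) as its step, so the change stays inside the normal noise of the measurement. The earlier pair, with the same change at another aromatic carbon, gave a 1.4-fold higher number from compound 1 to compound 2 (0.15 log units; within the scatter) as its step, so this is now a second placement of a methoxy group that leaves the reading within the scatter. Nothing available here explains why these readings stay so close.

Going by these compounds, only methoxy has been seen entering the ring, so it remains open whether an amine, a carboxylic acid or a longer chain such as butoxy at this position would move the reading beyond the scatter. On these data alone, whether any change to the shared core outside this ring would do so also remains open.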